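Swapping the sulfonyl aryl of a quinoline sulfone series

The source may hold more compounds than are shown below. What is called first, only, known or untested is meant among the compounds shown, and "the series" means these compounds.

Measured compounds:
- compound 1, `Cc1ccc2ncc(S(=O)(=O)c3ccc(C#N)cc3)c(N3CCC(C)CC3)c2c1`: 55%
- compound 2, `CC1CCN(c2c(S(=O)(=O)c3cc(F)cc(F)c3)cnc3ccc(Cl)cc23)CC1`: 93%
- compound 3, `COc1ccc2ncc(S(=O)(=O)c3cc(F)cc(F)c3)c(N3CCC(C)CC3)c2c1`: 30%

Three compounds share a core and were tested in an assay on isolated protein for displacement of a labelled ligand from metabotropic glutamate receptor 5 (Homo sapiens), with a stated time of 60 min, tested at 1 uM; on this read-out lower numbers stand for less inhibition and higher numbers for more inhibition at the one concentration tested (going by the name of the read-out). Compound 2 stands highest of the three. For the measured compounds named here, no single-place step links compound 2 and compound 1, so only the two values speak: compound 2 gives 93%, and compound 1 gives 55%. Going by the values given here, the one single-point step runs a number 63 percentage points lower from compound 2 to compound 3 (beyond the scatter), where the change sits on the core rather than on the sulfonyl aryl.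

Compound 4, `COc1ccc(S(=O)(=O)c2cnc3ccc(Cl)cc3c2N2CCC(C)CC2)cc1OC`, is not yet measured. It differs from compound 2 by 3,4-dimethoxyphenyl in place of 3,5-difluorophenyl on a sulfonyl sulfur. Among the compounds with values here, no measured step changes the group on the sulfonyl sulfur alone, so the bearing of the known steps is indirect: compound 1, which carries a different sulfonyl aryl together with a different core substituent, gives 55%, and compound 3 shows how sharply the number can fall within this core. A downward step is therefore expected, a number 33 percentage points lower from compound 2 to compound 4 (beyond the scatter), with wide uncertainty. Compound 4 is estimated at 60%, in the range 30% to 90%.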

Compound 4, a percentage reported as inhibition, at one concentration (the size of the read-out at that concentration, not a potency): 61%
Compound 4: middle estimate off by 1 percentage points, on the low side; the measured number falls inside the stated range.
By their numbers in this assay, from the lowest: compound 3; then compounds 1 and 4 (each within the scatter of the next); then compound 2.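

With the rest of the molecule held fixed, the group on the sulfonyl sulfur now has a measured effect of its own: in this assay, 3,4-dimethoxyphenyl in place of 3,5-difluorophenyl gives a number 32 percentage points lower from compound 2 to compound 4 (beyond the scatter). This position therefore responds to the choice of aryl, just as the core responds to methoxy in place of chloro, which gives a number 63 percentage points lower from compound 2 to compound 3 (beyond the scatter). No measurement at hand accounts for the step on the sulfonyl sulfur.

The compounds shown leave open whether the step follows from the arrival of the methoxy groups or the departure of the fluorines, and how a plain phenyl or a pyridyl group would read at this position. On these data alone, whether the same aryl exchange would give a similar step on the methoxy-bearing core of compound 3 also remains open.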